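Nitro in Place of Bromo: Expecting the Next Number

The compounds below may be only part of what the source reports. "The series", "measured", "known", "first", "only" and "open" are said of these compounds alone.

Going by the values given here, compound 2 `COc1cc2c(cc1OC)C(CC(=O)Nc1ccc(Br)cc1)CC2` gives the higher of the two numbers so far in a functional assay on the whole organism (strain Wistar) for inhibition, with Rattus norvegicus as the target, read by paw edema, with a stated time of 1 h, at a dose of 100 mg/kg (on this read-out higher numbers stand for more inhibition at the one dose given (going by the name of the read-out) and lower numbers for less inhibition), with 50%, while compound 1 `COc1cc2c(cc1OC)C(CC(=O)Nc1ccccc1)CC2` gives 31.3%. Among the compounds with values here, the single measured step, a number 18.7 percentage points higher from compound 1 to compound 2 (beyond the scatter), is the only guide available. Compound 3 `COc1cc2c(cc1OC)C(CC(=O)Nc1ccc([N+](=O)[O-])cc1)CC2` differs from compound 2 by nitro in place of bromo on an aromatic carbon. Within the data shown here, no measured step exchanges one group for another at this place, so the bromo step bears on it only indirectly. The expected step is therefore no change at the digits printed from compound 2 to compound 3 (within the scatter), nothing clear beyond the scatter. The estimate for compound 3 is 50%, in a range from 30% to 70%.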

Compound 3, a percentage reported as inhibition, in the whole organism at one dose (the size of the read-out at that dose, not a potency): 37.5%
Compound 3: the middle estimate sits 12.5 percentage points above what was measured; low and high end bracket the measured number.
By their numbers in this assay, from the lowest: compounds 1 and 3 (each within the scatter of the next); then compound 2.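

Exchanging bromo for nitro gives a number 12.5 percentage points lower from compound 2 to compound 3 (beyond the scatter) in this assay and so shows that this place on the aromatic ring tells the two groups apart. Nitro in place of hydrogen gives a number 6.2 percentage points higher from compound 1 to compound 3 (within the scatter) and leaves compound 3 not separated from compound 1, so a new group here does not by itself raise the number. Nothing available explains why the two groups differ.

Going by these compounds, whether an amine, a carboxylic acid or a methyl group at this place would match bromo stays open. Also open, on these data alone, is whether chloro or iodo would keep the gain seen with bromo.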